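From compound 2 to compound 3: adding a methoxy

This account rests on a few compounds, and the source may have more. Where it says the series, first, only, none or still open, it means among the compounds named here.

Compound 1 (`COc1ccc2[nH]c(-c3cn(-c4ccccc4)nc3-c3ccccc3)nc2c1`) at 2870 nM
Compound 2 (`Clc1ccc(-c2nn(-c3ccccc3)cc2-c2nc3ccccc3[nH]2)cc1`) at 1650 nM

For the measured compounds named here, in a functional assay on HeLa cells (Homo sapiens) for antiproliferative activity, read by MTT assay, with a stated time of 48 h (a lower number here means a stronger inhibitor, a higher number a weaker inhibitor), only two numbers are known so far, and compound 2 at 1650 nM lies within the scatter of compound 1. Compound 3 (`COc1ccc2[nH]c(-c3cn(-c4ccccc4)nc3-c3ccc(Cl)cc3)nc2c1`) has methoxy in place of hydrogen on an aromatic carbon of compound 2 (methoxy in place of hydrogen on an aromatic carbon). Going by the values given here, no measured pair shows this change alone. Compound 1 also carries a methoxy and gives 2870 nM in this assay and this points to no large change. The expected result is a 1.2-fold higher number from compound 2 to compound 3 (0.08 log units; within the scatter) and thus no step beyond the scatter. Compound 3 is estimated at 2000 nM (range 850 nM to 4500 nM).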

Compound 3, half-maximal inhibitory concentration: 3630 nM
Estimate against measurement, compound 3: 1.8-fold (0.26 log units) below; the measured number falls inside the stated range.
By their numbers in this assay, from the lowest: compounds 2, 1 and 3 (each within the scatter of the next, the first and the last beyond it).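

In this assay, for the compounds shown here, methoxy in place of hydrogen on an aromatic carbon of the six-membered carbon ring, part of the fused system, gives a 2.2-fold higher number from compound 2 to compound 3 (0.34 log units; beyond the scatter), the first step at this position to pass the scatter. Once that methoxy is present, chloro in place of hydrogen gives only a 1.3-fold higher number from compound 1 to compound 3 (0.10 log units; within the scatter), which stays within the scatter. No measurement available here explains either step. As far as these compounds go, it remains open whether a hydroxy, an amine or a longer chain such as ethoxy at the methoxy position would give a similar number, and whether the methoxy step holds without the chloro.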